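This account rests on a few compounds, and the source may have more. Where it says the series, first, only, none or still open, it means among the compounds named here.

Working notes on the series. In an assay for inhibition of RAC-alpha serine/threonine-protein kinase (Homo sapiens), read by HTRF, with a stated time of 1 h (a lower number here means a stronger inhibitor, a higher number a weaker inhibitor), compound 1 `Cn1ncc(Cl)c1-c1cc(C(=O)N[C@@H]2CNCC[C@H]2c2ccc(C(F)(F)F)cc2)oc1Cl` gives 9.3 nM. Compound 2 `Cn1ncc(Cl)c1-c1cc(C(=O)N[C@@H]2CN[C@H](CCN3CCCCC3)C[C@H]2c2ccc(Cl)c(Cl)c2)oc1Cl` gives 5.65 nM in this assay. Compound 3 `CC(=O)OCC[C@@H]1C[C@@H](c2ccc(F)c(F)c2)[C@H](NC(=O)c2cc(-c3c(Cl)cnn3C)c(Cl)o2)CN1` gives 3.4 nM in this assay. Compound 2 thus sits in the middle of the three numbers, both neighbours within the usual scatter of it, so the three compounds cannot be ranked against each other.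

Compound 4 `Cn1ncc(Cl)c1-c1cc(C(=O)N[C@@H]2CN[C@H](CC(=O)NCCO)C[C@H]2c2ccc(Cl)c(Cl)c2)oc1Cl` has not been measured. It differs from compound 2 by (2-hydroxyethyl)carbamoyl in place of (piperidin-1-yl)methyl on a saturated chain carbon bound to a saturated ring carbon. Among the measured compounds shown here, no measured pair isolates this change. The three measured compounds carry quite different groups at that part of the molecule and give numbers within the scatter of each other; on that basis the step from compound 2 to compound 4 is expected to be small, a 1.1-fold higher number from compound 2 to compound 4 (0.03 log units; within the scatter), with no clear direction. Compound 4 is therefore estimated at 6 nM in this assay, in a range from 2 nM to 20 nM.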

Compound 4, half-maximal inhibitory concentration: 1.41 nM
Compound 4: middle estimate off by 4.3-fold (0.63 log units), on the high side; the whole stated range lies above it.
By their numbers in this assay, from the lowest: compound 4; then compounds 3, 2 and 1 (each within the scatter of the next, the first and the last beyond it).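

In this assay, (2-hydroxyethyl)carbamoyl in place of (piperidin-1-yl)methyl gives a 4.0-fold lower number from compound 2 to compound 4 (0.60 log units; beyond the scatter), the first single-place change read in the series, and it shows that the number responds to the group at this place. The ring of the (piperidin-1-yl)methyl group is not needed for a low number here, since compound 4 has no ring at this place. No measurement available bears on the reason for this step. As far as these compounds go, whether the carbonyl or the hydroxyl carries the effect remains open. A carboxylic acid or an unsubstituted carbamoyl at this place would help to separate the two.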